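The compounds below may be only part of what the source reports. "The series", "measured", "known", "first", "only" and "open" are said of these compounds alone.

The series was examined in an ADME assay on HEK293 cells (Homo sapiens) for inhibition, read by CellTiter-Glo, with a stated time of 96 h, tested at 100 uM; a higher number here means more inhibition at the concentration tested (going by the name of the read-out), a lower number less inhibition. Compound 1 `CCOC(=O)/C=C/NC(=O)[C@H](O)C(C)(C)CO` gives -5% there, and its number is the lowest of the three measured, though the gap to compound 2 `COC(=O)/C=C/NC(=O)[C@@H](O)C(C)(C)CO`, which gives -2%, lies within the usual scatter, so the two cannot be told apart. Compound 3 `CC(C)(CO)[C@@H](O)C(=O)N/C=C\C(=O)OCc1ccccc1` gives 7%, a number that lies beyond the scatter from compound 1. None of the three shows any appreciable inhibition at the concentration tested.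

Compound 4 `CC(C)(C)OC(=O)/C=C/NC(=O)[C@H](O)C(C)(C)CO` has not yet been measured. It differs from compound 1 in one place: tert-butyl in place of ethyl on an oxygen next to a carbonyl group. Among the compounds with values here, no measured pair in this set shows the effect of such a change, so the expectation rests on the flat picture given by compounds 1, 2 and 3, all of which sit near zero. Compound 4 is therefore expected to remain without appreciable inhibition in this assay, with a step from compound 1 of a number 3 percentage points higher from compound 1 to compound 4 (within the scatter), that is, none beyond the scatter. The estimate for compound 4 is -2%, within a range from -12% to 10%.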

Compound 4, a percentage reported as inhibition, at one concentration (the size of the read-out at that concentration, not a potency): -1%
Beside the measured number, compound 4's estimate is 1 percentage points below it, within the range that was stated.
By their numbers in this assay, from the lowest: compounds 1, 2, 4 and 3 (each within the scatter of the next, the first and the last beyond it).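

In this assay, within the data shown here, tert-butyl in place of ethyl on an oxygen next to a carbonyl group gives a number 4 percentage points higher from compound 1 to compound 4 (within the scatter), the first comparison in this set of two compounds that differ in one place. It shows that this position accepts tert-butyl as well as ethyl, with no difference that can be told from the scatter and no appreciable inhibition at the concentration tested. No independent measurement is available to account for this result.

The compounds shown leave open whether a carboxylic acid, or a chain carrying an amine, would read the same way at this position. They also leave open whether the picture stays as flat when the rest of the core changes, for instance with a methyl ether in place of a hydroxyl group.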